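The source may hold more compounds than are shown below. What is called first, only, known or untested is meant among the compounds shown, and "the series" means these compounds.

In an assay on CHO cells for displacement of a labelled ligand from adenosine receptor A3 (Homo sapiens), read by scintillation counting, tested at 10 uM (a lower number here means less inhibition, a higher number more inhibition at the concentration tested (going by the name of the read-out)), compound 1 `CC(C)(C)Cc1c(-c2ccccn2)sc(N)c1C(=O)c1ccc(Cl)cc1` gives 1%. Compound 2 `CC(C)(C)Cc1c(-c2ccccc2)sc(N)c1C(=O)c1ccc(Cl)cc1Cl` gives 1% and compound 3 `COc1ccc(-c2sc(N)c(C(=O)c3cccc(C(F)(F)F)c3)c2CC(C)(C)C)cc1` gives 1% in this assay, so compound 1 sits level with both at the digits shown, with no difference beyond the scatter to either. Compound 4 `CC(C)(C)Cc1c(-c2cccs2)sc(N)c1C(=O)c1ccc(Cl)cc1` has not yet been measured. It differs from compound 1 by thiophen-2-yl in place of pyridin-2-yl on an aromatic carbon. Among the measured compounds shown here, no step between two measured compounds is available here, so nothing shows directly how such an exchange affects this assay. Since all three measured compounds, although they differ in several groups, sit at the same low reading, compound 4 is expected to show no step beyond the scatter, the expected step of a number 1 percentage points higher from compound 1 to compound 4 (within the scatter) being close to nothing. Compound 4 is estimated at 2% in this assay, within -8% to 14%.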

Compound 4, a percentage reported as inhibition, at one concentration (the size of the read-out at that concentration, not a potency): 1%
For compound 4 the middle estimate is 1 percentage points above the measured one; the range from low to high includes it.
By their numbers in this assay, from the lowest: compounds 1, 2, 3 and 4 (each within the scatter of the next).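

Among the compounds shown here, the step of no change at the digits printed from compound 1 to compound 4 (within the scatter) for thiophen-2-yl in place of pyridin-2-yl, next to the ring sulfur, is the first direct reading at this position in this assay. On the core of compound 1, a five-membered aromatic ring here reads the same as a six-membered one, although at so low a level the comparison has little room to reveal a difference. No measurement given here offers an explanation of this result.

As far as these compounds go, whether any group at this position can lift the reading remains open. A carboxylic acid or a morpholine ring there, for instance, might behave differently.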